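The source may hold more compounds than are shown below. What is called first, only, known or untested is meant among the compounds shown, and "the series" means these compounds.

Three related compounds have been measured so far in a functional assay on DU-145 cells (Homo sapiens) for inhibition, read by trypan blue exclusion, with a stated time of 96 h (a higher number here means a weaker inhibitor of growth, a lower number a stronger inhibitor of growth), and they do not all sit at the same level. Compound 1 (`COc1ccccc1/C=C(\C(=O)c1ccc(Cl)cc1)S(=O)(=O)Cc1ccc(Cl)cc1`) stands at 25000 nM on this read-out. Compound 2 (`Cc1ccc(C)c(/C=C(\C(=O)c2ccc(Cl)cc2)S(=O)(=O)c2ccc(Br)cc2)c1`) stands at 1000 nM and compound 3 (`Cc1ccc(S(=O)(=O)/C(=C/c2cc(C)ccc2C)C(=O)c2ccc(Cl)cc2)cc1`) at 1000 nM on the same read-out. Compound 3 thus shares the lowest number of the three with compound 2, and compound 1 lies well above both.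

Compound 4 (`Cc1ccc(C)c(/C=C(\C(=O)c2ccc(Cl)cc2)S(=O)(=O)Cc2ccc(Cl)cc2)c1`) is still unmeasured. It comes from compound 3 by one structural change (4-chlorobenzyl in place of 4-methylphenyl on a sulfonyl sulfur), namely 4-chlorobenzyl in place of 4-methylphenyl on a sulfonyl sulfur.

Among the measured compounds shown here, the only measured single change shows no change at the digits printed from compound 2 to compound 3 (within the scatter) for methyl in place of bromo on an aromatic carbon, but that swap is much smaller than the one at issue here. A closer hint comes from compound 1, which carries the same 4-chlorobenzyl on a sulfonyl sulfur and gives 25000 nM in this assay while also differing elsewhere in the core. The data cannot separate those two differences, so only part of that gap is expected to carry over. The expected size is a 5.0-fold higher number from compound 3 to compound 4 (0.70 log units; beyond the scatter) in this assay as an estimate, a move towards weaker inhibition of growth. Compound 4 is estimated at 5000 nM with 1500 nM to 20000 nM as the expected range.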

Compound 4, concentration for 50% growth inhibition: 10000 nM
Estimate against measurement, compound 4: 2.0-fold (0.30 log units) below; measured number inside the range.
By their numbers in this assay, from the lowest: compounds 2 and 3 (each within the scatter of the next); then compound 4; then compound 1.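

Among the compounds shown here, at the sulfonyl sulfur, this is the first change that moves the number beyond the scatter in this assay: replacing 4-methylphenyl with 4-chlorobenzyl gives a 10-fold higher number from compound 3 to compound 4 (1.00 log units; beyond the scatter), and replacing 4-bromophenyl with 4-chlorobenzyl gives a step of the same size, a 10-fold higher number from compound 2 to compound 4 (1.00 log units; beyond the scatter). So this position tolerated the earlier swap of methyl for bromo on the aromatic ring, yet responds clearly when the whole group on the sulfur is exchanged, and the 4-chlorobenzyl group goes with the weaker growth inhibition in both pairs. With 4-chlorobenzyl held in place, 2,5-dimethylphenyl in place of 2-methoxyphenyl on the double-bonded chain carbon gives a 2.5-fold lower number from compound 1 to compound 4 (0.40 log units; beyond the scatter), showing that this second site also changes the result on its own, while no measurement here accounts for either step.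

The 4-chlorobenzyl group differs from the two groups it replaces in more than one way, so these compounds cannot show whether the step follows the ring's chlorine or the extra carbon on the sulfur. A plain benzyl or a 4-chlorophenyl on the sulfonyl sulfur would separate those two, and a longer chain such as 2-phenylethyl would show how the trend continues.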